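A few compounds are considered here, and "the series" means these few. Any claim that something is new, unique, unknown or untested is made for them only; others in the source may bear on it.

Compound 1 `Fc1ccc(-c2nc3cc(C(F)(F)F)ccc3[nH]2)cc1`, in an ADME assay on MT4 cells (Homo sapiens) for cytotoxicity, read by MTT assay, with a stated time of 96 h; on this read-out higher numbers stand for lower toxicity in this test and lower numbers for higher toxicity in this test: 22000 nM
Compound 2 `CCN(CC)CC(=O)Nc1ccc(-c2nc3cc(C(F)(F)F)ccc3n2C)cc1`, in this assay: 9000 nM
Compound 3 `Fc1cccc(F)c1-c1nc2cc(Cl)c(Cl)cc2[nH]1`, in this assay: 17000 nM

Of these three numbers, compound 2 gives the lowest. Its nearest neighbour is compound 3, whose number lies within the usual scatter of compound 2, so the two cannot be ranked against each other; compound 1 stands further off, with a number beyond the scatter on the higher side. Compound 4 `Cn1c(-c2ccc(NC(=O)CN3CCN(c4ccccc4)CC3)cc2)nc2cc(C(F)(F)F)ccc21` is an unmeasured analogue of compound 2 that differs from it in one place, (4-phenylpiperazin-1-yl in place of diethylamino on a saturated chain carbon bound to a carbonyl carbon). Among the compounds with values here, no measured pair of compounds shares this change, so its effect in this assay cannot be read from the data at hand. The account therefore expects a step from compound 2 to compound 4 of a 1.3-fold lower number from compound 2 to compound 4 (0.11 log units; within the scatter), most likely no further than the scatter, with a mild lean towards a lower number rather than a higher one. For compound 4 the expected value in this assay is 7000 nM, with a range from 2000 nM to 25000 nM.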

Compound 4, half-maximal cytotoxic concentration: 1500 nM
Compound 4: the middle estimate sits 4.7-fold (0.67 log units) above what was measured; the measured number lies below the stated range.
By their numbers in this assay, from the lowest: compound 4; then compounds 2, 3 and 1 (each within the scatter of the next, the first and the last beyond it).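

Within the data shown here, the step of a 6.0-fold lower number from compound 2 to compound 4 (0.78 log units; beyond the scatter) is the first single change the set offers in this assay, and it shows that the number responds to the group on a saturated chain carbon bound to a carbonyl carbon. Here, the larger 4-phenylpiperazin-1-yl, with its non-aromatic and aromatic rings, goes with higher toxicity in this test than diethylamino does. Nothing at hand says why this change has this effect.

This one step cannot separate the contribution of the piperazine ring from that of the phenyl ring it carries. Going by these compounds, it therefore remains open whether a methylpiperazine or a morpholine at the same place would give a number closer to that of compound 2 or to that of compound 4.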